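The compounds below may be only part of what the source reports. "The series", "measured", "known", "first", "only" and "open" are said of these compounds alone.

Compound 1 `CC(C)n1nc(-c2ccnc3[nH]c(C4CCN(CC(=O)N(C)C)CC4)cc23)ccc1=O`: 3.1 uL/min
Compound 2 `CCn1cc(-c2ccnc3[nH]c(C4CCN(CC(=O)N(C)C)CC4)cc23)ccc1=O`: < 1 uL/min

In an ADME assay on cells (Hepatocyte, Rattus norvegicus) for metabolic stability (a higher number here means faster removal of the compound, a lower number slower removal), compound 1 gives 3.1 uL/min. For compound 2 the assay reports only a limit, < 1 uL/min, so compound 2 sits at the limit of < 1 uL/min in this assay, at which 1 of the 2 values shown sits, rather than at a known number. Going by the values given here, the one measured step, an at least 3.1-fold lower number from compound 1 to compound 2 (0.49 log units; beyond the scatter), concerns a different part of the molecule and so does not speak to the change now considered. Compound 3 `COc1cc(=O)n(C)cc1-c1ccnc2[nH]c(C3CCN(CC(=O)N(C)C)CC3)cc12` carries a group of 10 heavy atoms (7 carbon, 1 nitrogen, 2 oxygen; one six-membered aromatic ring with 1 hetero atom) in place of a group of 9 heavy atoms (7 carbon, 1 nitrogen, 1 oxygen; one six-membered aromatic ring with 1 hetero atom), on an aromatic carbon. Among the compounds with values here, with no step probing this change, no movement beyond the scatter is expected in this assay. Compound 3 is estimated to give 1 uL/min (range 0.4 uL/min to 2.5 uL/min). That amounts to an expected step of a number no lower from compound 2 to compound 3 (the limit leaves the size open).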

Compound 3, intrinsic clearance in a liver preparation (reported as CLH), per the amount of preparation that the assay uses in the Hepatocyte assay: < 1 uL/min
Compound 3 gave a limit, no number; the forecaster's own chance of this, stated with the estimate: 55%; the middle value sits exactly at the limit.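

In the Hepatocyte assay, the larger group on this aromatic carbon, opposite the ring nitrogen, gives an at least 3.1-fold lower number from compound 1 to compound 3 (0.49 log units; beyond the scatter); compound 2 and compound 3 both sit at a limit, so the step between them cannot be read. In a physicochemical assay for solubility, in phosphate buffer, at pH 7.4 (on this read-out lower numbers stand for lower solubility and higher numbers for higher solubility), compound 2 gives > 1000000 nM, which is a limit. In the same assay, compound 3 gives a real number, 670000 nM, and the change shows as an at least 1.4-fold lower number from compound 2 to compound 3 (0.17 log units; that floor lies within the scatter).

On these data alone, how far compound 2 and compound 3 lie beyond their shared limit for removal stays open. So does whether an amine or a carboxylic acid on this aromatic carbon would stay at that limit.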